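This account rests on a few compounds, and the source may have more. Where it says the series, first, only, none or still open, it means among the compounds named here.

Three related compounds have been tested in an ADME assay on HEK293 cells (Homo sapiens) for cytotoxicity, with a stated time of 72 h (a higher number here means that more compound is needed for the effect, a lower number that less compound is needed), and none of them gave an exact number. Compound 1 `C=C[C@@](C)(/C=C/c1ccc(O)cc1)CC/C=C(\C)CO` reads > 36600 nM as a limit of the assay and not a number. Compound 2 `CC(C)=CCC[C@](C)(/C=C/c1ccc(O)cc1)/C=C/c1cccc(Cl)c1` reads > 36600 nM as a limit too. Compound 3 `C=C[C@@](C)(/C=C/c1ccc(Nc2ccc(F)cc2)cc1)CCC=C(C)C` reads > 36600 nM as a limit as well. Compound 3 therefore has no exact value, and its place is the limit of > 36600 nM in this assay, at which 3 of the 3 values shown sit.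

Compound 4 `C=C[C@@](C)(/C=C/c1ccc(Nc2ccc(Cl)cc2)cc1)CCC=C(C)C` has not yet been measured and differs from compound 3 in one place. The change is chloro in place of fluoro on an aromatic carbon and in words it is chloro in place of fluoro on an aromatic carbon, para to a large group, so that 4-fluorophenyl becomes 4-chlorophenyl.

Among the measured compounds shown here, no step between two measured compounds is available to show how large such a swap might be. With compound 3 at > 36600 nM as a limit, the expectation is no step beyond the usual scatter in this assay and no particular direction. The estimated step is a number no higher from compound 3 to compound 4 (the limit leaves the size open) and it carries wide uncertainty. For compound 4 the estimate is 36600 nM with an expected range from 15000 nM to 80000 nM and the assay may well report only a limit again.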

Compound 4, half-maximal effective concentration: > 36600 nM
Compound 4 ended at the assay's limit; the forecaster's own chance of this, stated with the estimate: 80%; the middle value lies on the limit itself.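

In this assay compound 3 and compound 4 both stop at a limit of the assay and not at an exact number, so no step can be read for chloro in place of fluoro. Every compound shown gives this same reading: the limit of > 36600 nM in this assay, at which 4 of the 4 values shown sit. The compounds shown leave open what exact concentration any of them would need for the effect.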